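Aryl ring swap from compound 1 to compound 4: clearance notes

The source may hold more compounds than are shown below. What is called first, only, known or untested is meant among the compounds shown, and "the series" means these compounds.

Measured so far:
compound 1 `COc1cc(N(CC2CC2)c2ccc(Cl)c(Cl)c2)cnc1C(=O)[C@H]1C[C@@H]1C(=O)O` — 4.3 uL/min
compound 2 `COc1cc(N(CC2CC2)c2ccc(Cl)c3ccccc23)cnc1C(=O)CCCC(=O)O` — 6.8 uL/min
compound 3 `COc1cc(N(CC(C)(C)O)c2cccc(C(F)(F)F)c2)cnc1C(=O)[C@H]1C[C@@H]1C(=O)O` — "not determined" (no result reported)

In an ADME assay on cells (Hepatocyte, Homo sapiens) for metabolic stability, read by LC-MS, with a stated time of 60 min, tested at 1 uM (a lower number here means slower removal, a higher number faster removal of the compound), compound 1 gives 4.3 uL/min. Of the two compounds with a number, compound 1 has the lower one, and its nearest neighbour is compound 2 at 6.8 uL/min; the gap between these two falls within the usual scatter, so no order can be read between them. For compound 3 no result was reported in this assay.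

Compound 4 `COc1cc(N(CC2CC2)c2cc(Cl)c(F)cc2F)cnc1C(=O)[C@H]1C[C@@H]1C(=O)O` is yet to be measured. Against compound 1 it differs in one place: 5-chloro-2,4-difluorophenyl in place of 3,4-dichlorophenyl on a nitrogen on an aromatic ring. Within the data shown here, no step between measured compounds isolates a change of this kind, and the shared core, the cyclopropyl chain on the nitrogen and the acid-bearing side are unchanged. The expectation is therefore a step from compound 1 to compound 4 of a 1.2-fold higher number from compound 1 to compound 4 (0.07 log units; within the scatter), not beyond the scatter in either direction. For compound 4 the estimate in this assay is 5 uL/min, with a range from 2.2 uL/min to 11 uL/min.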

Compound 4, intrinsic clearance in a liver preparation (reported as CLH), per the amount of preparation that the assay uses: < 1.5 uL/min
Compound 4: a limit, no number (the forecaster's own chance of this, stated with the estimate: 5%); middle value at least 3.3-fold (0.52 log units) away from the limit.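

Among these compounds, at the aryl group on a nitrogen on an aromatic ring, 5-chloro-2,4-difluorophenyl in place of 3,4-dichlorophenyl gives the only step that can be read, and in this assay the change gives an at least 2.8-fold lower number from compound 1 to compound 4 (0.45 log units; beyond the scatter). Among the compounds shown here, the shared core, the cyclopropyl chain on the nitrogen and the acid-bearing side stay as in compound 1, so this step rests on the aryl swap alone, which the earlier compounds did not isolate. The reading for compound 4 is a limit and not a number: the limit of < 1.5 uL/min in this assay, at which 1 of the 4 values shown sits.

The swap alters fluorine and chlorine together, so the compounds shown do not tell which halogen change carries the step. From the compounds shown here alone, whether the step holds with a longer chain on the nitrogen, or with an amine in place of the carboxylic acid, also stays open.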